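The source may hold more compounds than are shown below. What is called first, only, known or untested is meant among the compounds shown, and "the series" means these compounds.

Compound 1, `COc1cc2c(Oc3ccc(NC(=O)c4nn(-c5ccccc5C)cc(C)c4=O)cc3)ccnc2cc1OCCCCCC(=O)NO`, is the starting point. In a functional assay on A549 cells (Homo sapiens) for inhibition, read by MTT assay, with a stated time of 72 h (a higher number here means a weaker inhibitor, a lower number a stronger inhibitor), compound 1 gives 1820 nM, the second highest of the three numbers measured. Compound 2, `COc1cc2c(Oc3ccc(NC(=O)c4nn(-c5ccccc5F)cc(C)c4=O)cc3F)ccnc2cc1OCCCCCC(=O)NO`, gives 1320 nM, which lies within the scatter of compound 1. Compound 3, `COc1cc2c(Oc3ccc(NC(=O)c4nn(-c5ccccc5C)ccc4=O)cc3)ccnc2cc1OCCCCCC(=O)NO`, gives 3920 nM; the one step that separates two of these compounds in a single place, a 2.2-fold higher number from compound 1 to compound 3 (0.33 log units; beyond the scatter), is a modest one and lies beyond the scatter.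

The step to compound 4, `COc1cc2c(Oc3ccc(NC(=O)c4nn(-c5ccccc5C)cc(C)c4=O)cc3)ccnc2cc1OCCCC(=O)NO`, changes compound 1 elsewhere: hydroxycarbamoyl in place of 2-(hydroxycarbamoyl)ethyl on a saturated chain carbon, three bonds along the chain from an oxygen on an aromatic ring. Going by the values given here, none of the measured steps touches that chain, so no measured step bears on this change; the one step that exists concerns the methyl on an aromatic carbon, and the gap between compound 1 and compound 2 sits within the scatter. The expectation therefore rests on the shared core alone and carries wide uncertainty. Compound 4 is expected to give 2500 nM, with a range from 900 nM to 7000 nM. That estimate means an expected step of a 1.4-fold higher number from compound 1 to compound 4 (0.14 log units; within the scatter).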

Compound 4, half-maximal inhibitory concentration: 4460 nM
The estimate for compound 4 lay 1.8-fold (0.25 log units) below the measured number; measured number inside the range.
By their numbers in this assay, from the lowest: compounds 2 and 1 (each within the scatter of the next); then compounds 3 and 4 (each within the scatter of the next).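

Shortening the chain is the first change at this position that can be read. In this assay, hydroxycarbamoyl in place of 2-(hydroxycarbamoyl)ethyl gives a 2.5-fold higher number from compound 1 to compound 4 (0.39 log units; beyond the scatter), a modest step, so the length of the chain carrying the hydroxycarbamoyl end matters to this read-out, whereas the earlier step concerned only a methyl on an aromatic carbon. No supporting information on these compounds accounts for the step.

With a single pair at this position, the compounds shown do not tell whether a chain longer than the 5-(hydroxycarbamoyl)pentyl of compound 1 would lower the number or raise it. They also leave open whether the hydroxycarbamoyl end itself is needed, which a carboxylic acid or an amine at the end of the same chain would test.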